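A few compounds are considered here, and "the series" means these few. Any claim that something is new, unique, unknown or untested is made for them only; others in the source may bear on it.

In a functional assay on MCF7 cells (Homo sapiens) for cytotoxicity, read by MTT assay, with a stated time of 48 h; on this read-out lower numbers stand for stronger inhibition and higher numbers for weaker inhibition: compound 1 `O=C(CSc1nnc(-c2ccncc2)o1)N/N=C/c1ccc(F)cc1` gives 13500 nM; compound 2 `O=C(CSc1nnc(-c2ccncc2)o1)N/N=C/c1ccc(Cl)cc1` gives 15300 nM; compound 3 `O=C(CSc1nnc(-c2ccncc2)o1)N/N=C/c1ccc([N+](=O)[O-])cc1` gives 31800 nM.

Compound 3 holds the highest number of the three; the steps of a 2.4-fold higher number from compound 1 to compound 3 (0.37 log units; beyond the scatter) and a 2.1-fold higher number from compound 2 to compound 3 (0.32 log units; beyond the scatter) both lie beyond the scatter, while a 1.1-fold higher number from compound 1 to compound 2 (0.05 log units; within the scatter) stays within it.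

Compound 4 `O=C(CSc1nnc(-c2ccncc2)o1)N/N=C/c1cc(Cl)ccc1O` differs from compound 3 by 5-chloro-2-hydroxyphenyl in place of 4-nitrophenyl on a carbon with a double bond to nitrogen. Among the compounds with values here, only one measured step bears directly on this: a 2.1-fold higher number from compound 2 to compound 3 (0.32 log units; beyond the scatter), and the present change runs that exchange backwards, chloro for nitro, which points to a modest fall in the number. Within the data shown here, the hydroxy part of the entering group has no counterpart among the measured compounds, so nothing can be read for it. Compound 4 is therefore expected to show a 2.1-fold lower number from compound 3 to compound 4 (0.33 log units; beyond the scatter), a modestly lower number. The estimate for compound 4 is 15000 nM, with a range from 7000 nM to 35000 nM.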

Compound 4, half-maximal inhibitory concentration: 5830 nM
Compound 4: middle estimate off by 2.6-fold (0.41 log units), on the high side, and the stated range ends above it.
By their numbers in this assay, from the lowest: compound 4; then compounds 1 and 2 (each within the scatter of the next); then compound 3.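

The 5-chloro-2-hydroxyphenyl group on this carbon gives the lowest number in the series, with a 5.5-fold lower number from compound 3 to compound 4 (0.74 log units; beyond the scatter) and a 2.6-fold lower number from compound 2 to compound 4 (0.42 log units; beyond the scatter) and also a 2.3-fold lower number from compound 1 to compound 4 (0.36 log units; beyond the scatter). Within the data shown here, the earlier compounds showed only that 4-nitrophenyl raises the number, whereas this change is the first to go below both 4-fluorophenyl and 4-chlorophenyl. No supporting data bear on why this exchange lowers the number.

The compounds shown leave open how much of the drop belongs to the hydroxy part and how much to the chloro part. Also open, on these data alone, is whether a methoxy group or an amine could stand in for the hydroxy.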